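From 3-fluorophenyl to 1,3-thiazol-2-yl on the amide-type nitrogen

This account rests on a few compounds, and the source may have more. Where it says the series, first, only, none or still open, it means among the compounds named here.

In a functional assay on SMMC-7721 cells (Homo sapiens) for inhibition, read by MTT assay, with a stated time of 48 h (on this read-out higher numbers stand for weaker inhibition and lower numbers for stronger inhibition), compound 1 `Nc1n[nH]c2cccc(-c3cccc(NC(=O)Nc4cccc(F)c4)c3)c12` gives 1240 nM. Compound 2 `Nc1n[nH]c2cccc(-c3cccc(NC(=O)Nc4ccc(Cl)cc4Cl)c3)c12` gives 1900 nM, and compound 3 `CC(C)c1cccc(NC(=O)Nc2cccc(-c3cccc4[nH]nc(N)c34)c2)c1` gives 280 nM. Compound 1 and compound 2 lie within the scatter of each other at the upper end of these three numbers, and compound 3 stands clearly lower.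

The next compound is compound 4 `Nc1n[nH]c2cccc(-c3cccc(NC(=O)Nc4nccs4)c3)c12`, which differs from compound 1 on an amide-type nitrogen: 1,3-thiazol-2-yl in place of 3-fluorophenyl on an amide-type nitrogen. In words, 1,3-thiazol-2-yl stands in place of 3-fluorophenyl.

Three measured steps alter the group at this place. Changing to 2,4-dichlorophenyl gives a 1.5-fold higher number from compound 1 to compound 2 (0.19 log units; within the scatter). Changing to 3-isopropylphenyl gives a 4.4-fold lower number from compound 1 to compound 3 (0.65 log units; beyond the scatter), and the same group set against 2,4-dichlorophenyl gives a 6.8-fold lower number from compound 2 to compound 3 (0.83 log units; beyond the scatter). Going by the values given here, none of the measured compounds carries a five-membered aromatic ring at this place, so the data offer no direct precedent. The one clear drop in the number comes with the isopropyl group of compound 3, which compound 4 lacks. A modest move towards a higher number is therefore expected, though with an uncertain direction.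

The estimate amounts to an expected 2.0-fold higher number from compound 1 to compound 4 (0.30 log units; within the scatter).

Compound 4 is expected at 2500 nM, with an estimated range of 800 nM to 8000 nM.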

Compound 4, half-maximal inhibitory concentration: 550 nM
Compound 4: the middle estimate sits 4.5-fold (0.66 log units) above what was measured, outside the stated range (below it).
By their numbers in this assay, from the lowest: compounds 3 and 4 (each within the scatter of the next); then compounds 1 and 2 (each within the scatter of the next).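

In this assay, a five-membered aromatic ring with 2 hetero atoms is accepted on the amide-type nitrogen: 1,3-thiazol-2-yl gives a 2.3-fold lower number from compound 1 to compound 4 (0.35 log units; beyond the scatter) and a 3.5-fold lower number from compound 2 to compound 4 (0.54 log units; beyond the scatter), so a lower number at this place no longer rests on 3-isopropylphenyl alone. Set against that group, the change gives a 2.0-fold higher number from compound 3 to compound 4 (0.29 log units; within the scatter), which leaves compound 3 and compound 4 unseparated in this cell read-out even though compound 4 has no isopropyl group, and ring type alone does not sort the series, since compound 3 carries a six-membered aromatic ring of carbon only, as do compound 1 and compound 2, which both stand clearly higher. No measurement in hand accounts for these steps.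

The compounds shown leave open whether the ring sulfur matters, which a 1,3-oxazol-2-yl group, with oxygen in its place, or a pyridin-2-yl group on the same nitrogen would test. They also leave open whether a methyl or isopropyl group on the 1,3-thiazol-2-yl ring would move the number further from that of compound 4.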